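Replacing hydroxy(phenyl)methyl with isopropoxy in compound 3

A few compounds are considered here, and "the series" means these few. Any claim that something is new, unique, unknown or untested is made for them only; others in the source may bear on it.

For the measured compounds named here, in an in vitro ADME assay on microsomes from liver (Homo sapiens) for metabolic stability (a higher number here means that the compound lasts longer, a lower number that the compound disappears faster), compound 3 `C[C@@H](c1ccc(Cl)cc1)N1Cc2cncn2C(C[C@@H](O)c2ccccc2)S1(=O)=O` gives 0.4 h, the lower of the two actual numbers so far. Compound 1 `C[C@@H](c1ccc(Cl)cc1)N1Cc2cncn2C(CC2(C)COC2)S1(=O)=O` gives 1.27 h. Compound 2 `CC(C)CC1n2cncc2CN(C2CC2)S1(=O)=O` gives only a limit of the assay, > 6.75 h.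

Compound 4 `CC(C)OCC1n2cncc2CN([C@@H](C)c2ccc(Cl)cc2)S1(=O)=O` differs from compound 3 as follows: isopropoxy in place of hydroxy(phenyl)methyl on a saturated chain carbon bound to a saturated ring carbon. In words, isopropoxy stands in place of hydroxy(phenyl)methyl on a saturated chain carbon bound to a saturated ring carbon.

Going by the values given here, one measured step bears on this change: a 3.2-fold lower number from compound 1 to compound 3 (0.50 log units; beyond the scatter). This modest step, beyond the scatter, brought in hydroxy(phenyl)methyl in place of 3-methyloxetan-3-yl at the same place. Read in reverse, it suggests that removing hydroxy(phenyl)methyl may raise the number, although isopropoxy is not the group present in compound 1, and a single step is thin support. The expected change is a 2.3-fold higher number from compound 3 to compound 4 (0.35 log units; beyond the scatter), a rise somewhat smaller than the measured step. For compound 4 the estimate is 0.9 h, with an expected range from 0.35 h to 2.4 h.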

Compound 4, half-life: 0.0833 h
Beside the measured number, compound 4's estimate is 11-fold (1.03 log units) above it, outside the stated range (below it).
By their numbers in this assay, from the lowest: compound 4; then compound 3; then compound 1. At a limit, above all of these: compound 2.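

In this assay, removing hydroxy(phenyl)methyl with its six-membered aromatic ring does not raise the number at this place: putting isopropoxy there gives a 4.8-fold lower number from compound 3 to compound 4 (0.68 log units; beyond the scatter). Set against 3-methyloxetan-3-yl, the same isopropoxy gives a 15-fold lower number from compound 1 to compound 4 (1.18 log units; beyond the scatter), so on the shared core the choice of group on this saturated chain carbon alone moves the number by a wide margin. Nothing measured here explains why isopropoxy gives the lowest number of the three.

The compounds shown cannot tell whether the low number goes with the oxygen of isopropoxy or with its carbons. A carboxylic acid or an amine at this same place, on the core of compound 4, would show how far the number follows the group's chemical type rather than its size.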